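The source may report more compounds than this note shows. Statements on the series, on what has been measured and on what is new or still open speak of the compounds shown alone.

Measured compounds:

compound 1 `COc1ccc([C@@H]2CC(=O)c3c(O)cc(OCc4cn(Cc5ccc(C(F)(F)F)cc5)nn4)cc3O2)cc1O` – 17700 nM
compound 2 `C#CCOc1cc(O)c2c(c1)O[C@H](c1ccc(OC)c(O)c1)C/C2=N\O` – 19100 nM
compound 3 `COc1ccc([C@@H]2CC(=O)c3c(O)cc(OCc4cn(Cc5cccc(Cl)c5)nn4)cc3O2)cc1O` – 18200 nM

In a functional assay on RAW264.7 cells (Mus musculus) for inhibition, read by Griess assay, with stated times of 2 h and 24 h (on this read-out lower numbers stand for stronger inhibition and higher numbers for weaker inhibition), compound 3 gives 18200 nM. The three numbers lie within the usual scatter of one another, so compound 3 cannot be set apart from compound 1 or compound 2 on this read-out.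

Compound 4 `COc1ccc([C@@H]2CC(=O)c3c(O)cc(OCc4cn(Cc5ccccc5)nn4)cc3O2)cc1O` differs from compound 3 in one place: hydrogen in place of chloro on an aromatic carbon. Among the measured compounds shown here, the change sits on the outer ring of the same side chain that was altered in the one measured step bearing on it, a 1.0-fold higher number from compound 1 to compound 3 (0.01 log units; within the scatter), which exchanged a larger group on that ring and stayed within the scatter. Nothing measured here points to a difference in this assay arising from a substituent on that ring.

Compound 4 is therefore expected to give about 18000 nM in this assay, with a range from 9000 nM to 36000 nM. The expected step of a 1.0-fold lower number from compound 3 to compound 4 (0.00 log units; within the scatter) is, on this estimate, none beyond the scatter.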

Compound 4, half-maximal inhibitory concentration: 11000 nM
Estimate against measurement, compound 4: 1.6-fold (0.21 log units) above; low and high end bracket the measured number.
By their numbers in this assay, from the lowest: compounds 4, 1, 3 and 2 (each within the scatter of the next).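

Replacing chloro with hydrogen on the outer ring gives a 1.7-fold lower number from compound 3 to compound 4 (0.22 log units; within the scatter) in this assay, and replacing trifluoromethyl with hydrogen gives a 1.6-fold lower number from compound 1 to compound 4 (0.21 log units; within the scatter) on the same read-out. Compound 4 carries no substituent on that ring, so it adds the bare ring as a reference point, and the numbers for the bare, chloro and trifluoromethyl rings cannot be told apart. On these three compounds, neither group is needed on the ring for a number of this size, and no evidence is available to explain the small differences. The compounds shown leave open whether an amine or a carboxylic acid on this ring would give a number beyond the scatter of these three. They also leave open what a longer chain in place of the benzyl group would do.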